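The source may hold more compounds than are shown below. What is called first, only, known or untested is meant among the compounds shown, and "the series" means these compounds.

In an ADME assay on the whole organism (Rattus norvegicus, strain Fischer 344) for pharmacokinetics, with a stated time of 8 h, at a dose of 3 mg/kg by the oral route (a lower number here means less compound in the circulation, a higher number more compound in the circulation at the dose given), compound 1 `NC(=O)c1sc2nccc(N3CCC[C@H](COCC(=O)N4CCOCC4)C3)c2c1N`, which carries (morpholin-4-yl)carbonyl on the ether chain, gives 756 ng.h/mL. Compound 2 `COC[C@H]1CCCN(c2ccnc3sc(C(N)=O)c(N)c23)C1`, with hydrogen in that place, gives 227 ng.h/mL. Compound 3 `Cc1noc(COC[C@H]2CCCN(c3ccnc4sc(C(N)=O)c(N)c34)C2)n1`, with 3-methyl-1,2,4-oxadiazol-5-yl there, gives 563 ng.h/mL. Two steps place that value: a 1.3-fold lower number from compound 1 to compound 3 (0.13 log units; within the scatter), and a 2.5-fold higher number from compound 2 to compound 3 (0.39 log units; beyond the scatter). It therefore sits level with the morpholine-bearing compound and clear of the one with hydrogen.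

Compound 4 `Cn1ccnc1COC[C@H]1CCCN(c2ccnc3sc(C(N)=O)c(N)c23)C1` makes a single change: 1-methyl-1H-imidazol-2-yl in place of 3-methyl-1,2,4-oxadiazol-5-yl on a saturated chain carbon bound to an oxygen on a saturated carbon. The new group is 1-methyl-1H-imidazol-2-yl, in place of 3-methyl-1,2,4-oxadiazol-5-yl. Among the measured compounds shown here, no measured step exchanges these two groups directly. The closest evidence is the exchange of one group for another, a 1.3-fold lower number from compound 1 to compound 3 (0.13 log units; within the scatter), whereas removing the group altogether gave a larger step, a 3.3-fold lower number from compound 1 to compound 2 (0.52 log units; beyond the scatter). No change beyond the scatter is therefore expected in this assay, and the estimated step is a 1.3-fold lower number from compound 3 to compound 4 (0.10 log units; within the scatter). For compound 4 the estimated value is 450 ng.h/mL, with an expected range from 160 ng.h/mL to 1250 ng.h/mL.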

Compound 4, area under the concentration-time curve: 45 ng.h/mL
The estimate for compound 4 lay 10-fold (1.00 log units) above the measured number; the measured number lies below the stated range.
By their numbers in this assay, from the lowest: compound 4; then compound 2; then compounds 3 and 1 (each within the scatter of the next).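

In this assay, the ring on this ether chain proves far from interchangeable: 1-methyl-1H-imidazol-2-yl and 3-methyl-1,2,4-oxadiazol-5-yl have the same number of heavy atoms, yet the exchange gives a large step (a 13-fold lower number from compound 3 to compound 4 (1.10 log units; beyond the scatter)). The earlier groups both gave higher numbers than hydrogen, whereas this one falls below it (a 5.0-fold lower number from compound 2 to compound 4 (0.70 log units; beyond the scatter)), so a group at this place can also take the number down. The gap to the morpholine-bearing compound is similarly large (a 17-fold lower number from compound 1 to compound 4 (1.23 log units; beyond the scatter)).

Nothing available explains this drop. As far as these compounds go, it remains open whether an imidazole without its methyl group, a pyridine ring or a carboxylic acid on the same chain would give a number nearer that of compound 4 or that of compound 3.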